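This account rests on a few compounds, and the source may have more. Where it says the series, first, only, none or still open, it means among the compounds named here.

Measured in a functional assay for inhibition, with Rattus norvegicus as the target; a lower number here means a stronger inhibitor, a higher number a weaker inhibitor:

Compound 1, `C/N=c1\c(O)c(O)\c1=N/Cc1ccc(C#N)cc1`. In this assay compound 1 gives > 30000 nM, which is a limit of the assay and not a number.
Compound 2, `CC(C)(C)/N=c1\c(O)c(O)\c1=N/Cc1ccc(C#N)cc1`. In this assay compound 2 gives 270 nM.
Compound 3, `CN(c1c(NCc2ccc(C#N)cc2)c(=O)c1=O)C(C)(C)C`. In this assay compound 3 gives 18300 nM.

One measured step connects two of these. The change methyl in place of tert-butyl on a double-bonded nitrogen brings an at least 110-fold higher number from compound 2 to compound 1 (2.04 log units; beyond the scatter); the measured value of compound 1 sits at the limit of > 30000 nM in this assay, at which 1 of the 3 values shown sits, so the true size of the step is not known. Compound 3 carries a different core; the difference between the two cores is not broken down here. Its value is the highest of the two numbers in this assay.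

Not yet measured is compound 4, `CN(C)c1c(NCc2ccc(C#N)cc2)c(=O)c1=O`. It differs from compound 3 by methyl in place of tert-butyl on a nitrogen on an aromatic ring. This is the same kind of change as that from compound 2 to compound 1, not the same: in one case the nitrogen is double-bonded with an aromatic carbon as its other neighbour, in the other it is a nitrogen on an aromatic ring whose other neighbours are an aromatic carbon and a saturated chain carbon. Taking the measured step as the nearest guide, the step from compound 3 to compound 4 in this assay is expected to be of similar direction, an 8.2-fold higher number from compound 3 to compound 4 (0.91 log units; beyond the scatter), resting on the step from compound 2 to compound 1 and on the starting value of compound 3. Compound 4 is therefore expected to give about 150000 nM, between 30000 nM and 1000000 nM, most likely reported only as a limit.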

Compound 4, half-maximal inhibitory concentration: > 30000 nM
Compound 4 was reported as a limit; the forecaster's own chance of this, stated with the estimate: 85%; the middle value does not contradict the limit.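

In this assay compound 4 gives > 30000 nM, which is a limit of the assay and not a number. Methyl in place of tert-butyl on a nitrogen on an aromatic ring brings an at least 1.6-fold higher number from compound 3 to compound 4 (0.21 log units; that floor lies within the scatter); this agrees in direction with the change on the core of compound 2, but this floor alone does not establish a real shift on the core of compound 3. The result therefore shows that the earlier step is not contradicted on the second core, but it does not show that the change carries over with the same size: the same change on two cores in this assay, an at least 110-fold higher number (2.04 log units; beyond the scatter) from compound 2 to compound 1 and an at least 1.6-fold higher number (0.21 log units; that floor lies within the scatter) from compound 3 to compound 4; the limit leaves it open whether they differ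

Open, from the compounds shown here alone, is where ethyl or isopropyl in place of tert-butyl would fall on each core, and whether a cyclopropyl group on the same nitrogen would behave more like methyl or like tert-butyl. Also open is how far the two methyl compounds lie beyond the limit, so the size of neither step can be fixed from these data: the limit of > 30000 nM in this assay, at which 2 of the 4 values shown sit.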